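The source may report more compounds than this note shows. Statements on the series, on what has been measured and on what is new or still open speak of the compounds shown alone.

Measured compounds:

Compound 1, `O=C1N=C(N2N=C(c3ccccc3)CC2c2ccccc2O)S/C1=C1/C(=O)Nc2ccccc21`: in a functional assay on cells (Leukemia cell, Homo sapiens) for cytotoxicity, read by sulforhodamine B assay, with a stated time of 48 h (on this read-out lower numbers stand for stronger inhibition of growth and higher numbers for weaker inhibition of growth), compound 1 gives 48800 nM.
Compound 2, `O=C1N=C(N2N=C(c3ccccc3)CC2c2ccccc2O)S/C1=C1/C(=O)Nc2ccc(Br)cc21`: in this assay compound 2 gives 1050 nM.
Compound 3, `COc1ccc(C2=NN(C3=NC(=O)/C(=C4\C(=O)Nc5ccccc54)S3)C(c3ccc(OC)cc3)C2)cc1`: in this assay compound 3 gives 100000 nM.

Compound 1 and compound 2 share one core and differ in a single place, (bromo in place of hydrogen on an aromatic carbon). The step is a 46-fold lower number from compound 1 to compound 2 (1.67 log units; beyond the scatter), a large move toward stronger growth inhibition that lies well beyond the scatter.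

Compound 3 carries a different core; how the core of compound 3 differs from the core of compound 1 is not broken down here. In this assay compound 3 stands at the weak end of the three measured values, its number being higher than that of compound 1 and much higher than that of compound 2, both gaps beyond the scatter.

Compound 4, `COc1ccc(C2=NN(C3=NC(=O)/C(=C4\C(=O)Nc5ccc(Br)cc54)S3)C(c3ccc(OC)cc3)C2)cc1`, is not yet measured. It is related to compound 3 exactly as compound 2 is related to compound 1: bromo in place of hydrogen on an aromatic carbon. The place of the change is described in the same words for both pairs, so this is the same change made on the second core. Among the measured compounds shown here, the only guide to its size is the single earlier step of a 46-fold lower number from compound 1 to compound 2 (1.67 log units; beyond the scatter), observed on one core with one pair of compounds; whether the second core responds alike is unknown, and a value as high as that of compound 3 may sit near the top of what the assay resolves, which would compress the apparent step. A somewhat smaller move is therefore expected: the step from compound 3 to compound 4 is estimated at a 20-fold lower number from compound 3 to compound 4 (1.30 log units; beyond the scatter). For compound 4 the expected value in this assay is 5000 nM, with a range from 1000 nM to 40000 nM.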

Compound 4, concentration for total growth inhibition: 62700 nM
The estimate for compound 4 lay 13-fold (1.10 log units) below the measured number, and the stated range ends below it.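

In this assay, among the compounds shown here, bromo in place of hydrogen on an aromatic carbon gives a 1.6-fold lower number from compound 3 to compound 4 (0.20 log units; within the scatter), so on the core of compound 3 the change produces no step that can be told from the scatter. The change therefore does not carry over in size from the core of compound 1 to the core of compound 3, and the two steps differ clearly: the same change on two cores in this assay, a 46-fold lower number (1.67 log units; beyond the scatter) from compound 1 to compound 2 and a 1.6-fold lower number (0.20 log units; within the scatter) from compound 3 to compound 4, 29-fold (1.46 log units) apart, beyond the scatter of two such steps. This rests on a single pair for each core, and the two cores differ in more than one place, so it shows that the effect of bromo depends on the core here but does not show which feature of the core is responsible, nor how the change would behave on any third core.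

Still open, from the compounds shown here alone, is whether a core carrying only a hydroxy group or only a methoxy group in place of the full set of differences would follow compound 1 and compound 2 or compound 3 and compound 4. Also open, going by these compounds, is whether chloro, fluoro or an amine on the same aromatic carbon would give a step of the same kind on both cores.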